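The compounds below may be only part of what the source reports. "The series", "measured", "known", "first", "only" and "open" are said of these compounds alone.

In an ADME assay on CCRF-CEM cells (Homo sapiens) for antiproliferative activity, with a stated time of 48 h (a lower number here means a stronger inhibitor, a higher number a weaker inhibitor), compound 1 `C=C(Br)C(=O)Nc1ccc(/C=C/C(=O)c2ccccc2)cc1` gives 4000 nM while compound 2 `C=C(Br)C(=O)Nc1ccc(/C=C/C(=O)c2ccc(F)cc2)cc1` gives 1100 nM and compound 3 `C=C(Br)C(=O)Nc1ccc(/C=C/C(=O)c2ccc(Cl)c(Cl)c2)cc1` gives 1700 nM in the same read-out. With a 1.5-fold higher number from compound 2 to compound 3 (0.19 log units; within the scatter) these last two sit level, so compound 2 holds no real lead over compound 3. Compound 1 stands apart, with a 3.6-fold lower number from compound 1 to compound 2 (0.56 log units; beyond the scatter) and a 2.4-fold lower number from compound 1 to compound 3 (0.37 log units; beyond the scatter) as modest steps.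

The next compound is compound 4 `C=C(Br)C(=O)Nc1ccc(/C=C/C(=O)c2ccc(C)cc2)cc1` and it carries methyl in place of fluoro on an aromatic carbon as methyl in place of fluoro on an aromatic carbon, para to a large group. For the measured compounds named here, no measured compound holds a methyl, so the expectation rests on analogy alone. Going by the values given here, the closest precedent is the exchange of 4-fluorophenyl for 3,4-dichlorophenyl, which gave a 1.5-fold higher number from compound 2 to compound 3 (0.19 log units; within the scatter) and so no shift that can be told from noise. The step from compound 1 to compound 2, at a 3.6-fold lower number from compound 1 to compound 2 (0.56 log units; beyond the scatter) as the largest measured, sets the outer size.

A small move toward a higher number is expected, with a 1.6-fold higher number from compound 2 to compound 4 (0.21 log units; within the scatter) as the estimated step and nothing clearly beyond the scatter anticipated. The estimate for compound 4 is 1800 nM with 800 nM to 4000 nM as the expected span.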

Compound 4, half-maximal inhibitory concentration: 1800 nM
For compound 4 middle estimate and measured number coincide at the digits printed; low and high end bracket the measured number.
By their numbers in this assay, from the lowest: compounds 2, 3 and 4 (each within the scatter of the next); then compound 1.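

Methyl and fluoro at this position, para to a large group, cannot be told apart in this assay given a 1.6-fold higher number from compound 2 to compound 4 (0.21 log units; within the scatter) and 4-methylphenyl also sits level with 3,4-dichlorophenyl given a 1.1-fold higher number from compound 3 to compound 4 (0.02 log units; within the scatter) in the same read-out. With a 2.2-fold lower number from compound 1 to compound 4 (0.35 log units; beyond the scatter) as a modest step, a methyl also separates from the unsubstituted phenyl of compound 1, so among these four compounds the move to a lower number does not require a halogen on the ring, and the three substituted compounds form one level group. No measurement of any property of these groups accompanies the numbers, and the data offer no account of why the three sit level.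

Open, on these data alone, is whether a group of another kind at this position, such as an amine, a carboxylic acid or a longer chain like propyl, would stay within this level group or leave it. Also open, as far as these compounds go, is whether the same level reading would hold in another cell line or with the rest of the core changed.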